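Swapping methyl for cyclopropyl on the quinazoline amine

The compounds below may be only part of what the source reports. "The series", "measured", "known", "first", "only" and "open" are said of these compounds alone.

Measured so far, in a functional assay on HCT-116 cells (Homo sapiens) for inhibition, read by luminescence and resazurin assay, with a stated time of 3 days; a higher number here means a weaker inhibitor, a lower number a stronger inhibitor:
compound 1, `CNc1nc(NCc2ccc(C(=O)Nc3ccc(F)cc3)cc2)c2ccccc2n1`, gives 2900 nM.
compound 3, `CNc1nc(NCc2ccc(NC(=O)c3ccc(F)cc3)cc2)c2ccccc2n1`, gives 1600 nM.
compound 2, `CN1CCN(c2nc(NCc3ccc(NC(=O)c4ccncc4)cc3)c3ccccc3n2)CC1`, gives > 20000 nM, which is a limit of the assay and not a number.

Among the two plain numbers, compound 1 carries the higher one, and its nearest neighbour is compound 3, with the step of a 1.8-fold lower number from compound 1 to compound 3 (0.26 log units; within the scatter). That step turns the amide round, placing ((4-fluorophenyl)carbonyl)amino where compound 1 has (4-fluorophenyl)carbamoyl, and it stays within the scatter, so the two compounds cannot be ordered. Within the data shown here, compound 2 differs from compound 1 in more than one place, so its limit, recorded at the limit of > 20000 nM in this assay, at which 1 of the 3 values shown sits, tells only that compound 2 sits there and nothing about any single change.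

Compound 4, `O=C(Nc1ccc(F)cc1)c1ccc(CNc2nc(NC3CC3)nc3ccccc23)cc1`, is not yet measured. It differs from compound 1 by cyclopropyl in place of methyl on a nitrogen on an aromatic ring. Among the measured compounds shown here, no measured step touches this nitrogen, so the measured pairs give no direction for it. A change this small, on a part of the molecule that the measured steps leave untouched, is expected to give a step of a 1.3-fold lower number from compound 1 to compound 4 (0.12 log units; within the scatter) that stays within the scatter.

Compound 4 is therefore estimated at 2200 nM, within a range from 600 nM to 8000 nM.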

Compound 4, half-maximal inhibitory concentration: 2700 nM
Beside the measured number, compound 4's estimate is 1.2-fold (0.09 log units) below it; measured number inside the range.
By their numbers in this assay, from the lowest: compounds 3, 4 and 1 (each within the scatter of the next). At a limit, above all of these: compound 2.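

In this assay, among these compounds, cyclopropyl in place of methyl on this nitrogen gives a 1.1-fold lower number from compound 1 to compound 4 (0.03 log units; within the scatter), the first measured step at this position. The earlier compounds shown here said nothing about this nitrogen on its own, whereas this pair shows that a three-membered ring of carbon and a methyl cannot be told apart here, even though the cyclopropyl brings more heavy atoms. Among the compounds shown here, nothing measured so far explains why the two groups read alike at this nitrogen.

As far as these compounds go, whether the same nitrogen would accept a group of another kind, such as a longer chain ending in an amine or a carboxylic acid, remains open, as does whether cyclopropyl would read the same with the amide turned round as in compound 3. Compound 2 gives > 20000 nM, which is a limit of the assay and not a number. Compound 2 differs from compound 1 in more than one place, so it cannot settle either question.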